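Benzyl variation on the triazolyl-methylthio triazine series

This account rests on a few compounds, and the source may have more. Where it says the series, first, only, none or still open, it means among the compounds named here.

Measured so far in a functional assay on ECa-109 cells for antiproliferative activity against ECa-109 cell line (Homo sapiens), read by MTT assay, with a stated time of 48 h; a lower number here means a stronger inhibitor, a higher number a weaker inhibitor:
compound 1 `Clc1ccc(Cn2cc(CSc3nnc(-c4ccccc4)c(-c4ccccc4)n3)nn2)cc1` gives 24200 nM.
compound 2 `Fc1ccc(Cn2cc(CSc3nnc(-c4ccccc4)c(-c4ccccc4)n3)nn2)cc1` gives 19100 nM.
compound 3 `COc1ccc(Cn2cc(CSc3nnc(-c4ccccc4)c(-c4ccccc4)n3)nn2)cc1` gives 28400 nM.

The three compounds share one core and differ only in the group on the benzyl ring. All three sit close together: from compound 1 to compound 2 the change is a 1.3-fold lower number from compound 1 to compound 2 (0.10 log units; within the scatter), from compound 1 to compound 3 it is a 1.2-fold higher number from compound 1 to compound 3 (0.07 log units; within the scatter), and from compound 2 to compound 3 it is a 1.5-fold higher number from compound 2 to compound 3 (0.17 log units; within the scatter). Compound 3 therefore stands at the high end of the three numbers, but none of the gaps to it is outside the scatter, so no ordering among the three is claimed.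

Compound 4 `c1ccc(-c2nnc(SCc3cn(Cc4ccc5ccccc5c4)nn3)nc2-c2ccccc2)cc1` carries the change (naphthalen-2-yl in place of 4-methoxyphenyl on a saturated chain carbon bound to an aromatic nitrogen). For the measured compounds named here, no measured step involves a naphthalen-2-yl group, so the measured steps bear on it only indirectly: the three benzyl variations all left this assay essentially unchanged. On that basis the expected step of a 1.3-fold lower number from compound 3 to compound 4 (0.11 log units; within the scatter) is none beyond the scatter, with wide uncertainty since the entering group is larger than any tried. Compound 4 is estimated at 22000 nM, expected to lie between 8000 nM and 60000 nM.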

Compound 4, half-maximal inhibitory concentration: > 100000 nM
Compound 4 gave a limit, no number; the forecaster's own chance of this, stated with the estimate: 10%; middle value at least 4.5-fold (0.65 log units) from the limit.
By their numbers in this assay, from the lowest: compounds 2, 1 and 3 (each within the scatter of the next). At a limit, above all of these: compound 4.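

In this assay compound 4 gives a limit and not a number: the limit of > 100000 nM in this assay, at which 1 of the 4 values shown sits. Even read against that limit, this place on a saturated chain carbon bound to an aromatic nitrogen responds to the change, with an at least 3.5-fold higher number from compound 3 to compound 4 (0.54 log units; beyond the scatter) and an at least 5.2-fold higher number from compound 2 to compound 4 (0.71 log units; beyond the scatter) and an at least 4.1-fold higher number from compound 1 to compound 4 (0.61 log units; beyond the scatter) as the three steps. Naphthalen-2-yl is thus the only change shown at this place that moves the number beyond the scatter, whereas the swaps among the 4-chlorophenyl, 4-fluorophenyl and 4-methoxyphenyl groups of compounds 1, 2 and 3 stayed within it.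

Going by these compounds, how far compound 4 lies past its limit stays open. Also open, on these data alone, is how a naphthalen-1-yl group, an unsubstituted benzyl group, or a benzyl ring carrying an amine or a carboxylic acid would read at this place.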